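This account rests on a few compounds, and the source may have more. Where it says the series, first, only, none or still open, it means among the compounds named here.

In a functional assay on SK-OV-3 cells (Homo sapiens) for antiproliferative activity, read by MTT assay, with a stated time of 72 h (on this read-out higher numbers stand for weaker inhibition and lower numbers for stronger inhibition), compound 1 (`CCNC(=O)CCc1cccc2c1B(O)OC2`) gives > 100000 nM, which is a limit of the assay and not a number. Within the data shown here, compound 2 (`O=C(CCc1cccc2c1B(O)OC2)Nc1ccc(Br)cc1`) gives 9200 nM, the only true number so far. The next compound, compound 3 (`Cc1ccc(NC(=O)CCc2cccc3c2B(O)OC3)cc1`), differs from compound 2 at a single place: methyl in place of bromo on an aromatic carbon.

Among the measured compounds shown here, only one measured step bears on this change. It is an at least 10-fold lower number from compound 1 to compound 2 (1.03 log units; beyond the scatter), a large step that puts 4-bromophenyl in place of ethyl on an amide-type nitrogen. That step exchanged a whole group, so it does not isolate the bromo, and the aromatic ring stays in compound 3. The expected result is a 1.3-fold higher number from compound 2 to compound 3 (0.12 log units; within the scatter), with no change beyond the scatter. For compound 3, the estimated value is 12000 nM, with an expected range from 4500 nM to 35000 nM.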

Compound 3, half-maximal inhibitory concentration: 860 nM
Beside the measured number, compound 3's estimate is 14-fold (1.14 log units) above it; the measured number lies below the stated range.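

Bromo and methyl each add one heavy atom on an aromatic carbon, para to a large group, yet this exchange gives an 11-fold lower number from compound 2 to compound 3 (1.03 log units; beyond the scatter). The earlier step replaced a whole group, whereas this one shows that in this assay the group on this carbon matters on its own, and that keeping the aromatic ring does not fix the value. Setting 4-methylphenyl in place of ethyl on the amide nitrogen gives an at least 110-fold lower number from compound 1 to compound 3 (2.06 log units; beyond the scatter), and this size is only a bound because compound 1 gives a limit and not a number: the limit of > 100000 nM in this assay, at which 1 of the 3 values shown sits.

Only bromo and methyl are shown on this carbon, so how a methoxy group, an amine or a carboxylic acid there would read remains open. Why methyl and bromo differ so widely also remains unexplained by these compounds.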